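Turning the Double Bond: E to Z in a Chalcone-Like Enone

The source may hold more compounds than are shown below. What is called first, only, known or untested is meant among the compounds shown, and "the series" means these compounds.

Among the compounds with values here, compound 2 `CC(=O)OC/C(=C\c1ccc(Cl)cc1)C(=O)c1ccc(Cl)cc1` gives the lowest of the two numbers so far in a functional assay on SW1573 cells (Homo sapiens) for inhibition, read by sulforhodamine B assay, with a stated time of 48 h (on this read-out higher numbers stand for weaker inhibition of growth and lower numbers for stronger inhibition of growth), at 3400 nM. Within the data shown here, its nearest neighbour, compound 1 `CC(=O)OC/C(=C\C1CCCCC1)C(=O)c1ccc(Cl)cc1`, gives 18000 nM in this assay, and the only measured step, a 5.3-fold lower number from compound 1 to compound 2 (0.72 log units; beyond the scatter), concerned the exchange of a ring and not the shape of the chain. Compound 3 `CC(=O)OC/C(=C/c1ccc(Cl)cc1)C(=O)c1ccc(Cl)cc1` differs from compound 2 only in that (the two compounds have the same atoms and bonds and differ only in configuration as drawn: 1 of 1 stereo elements differ; a double bond is drawn E in compound 2 and Z in compound 3). Among the measured compounds shown here, no measured step bears on a change of configuration alone, so there is nothing in the numbers to indicate a direction or a size; compound 3 is therefore expected to sit close to compound 2 in this assay, with a 1.2-fold higher number from compound 2 to compound 3 (0.07 log units; within the scatter) expected to stay within the scatter but with a wide allowance for the unknown. Compound 3 is estimated at 4000 nM, within a range from 1000 nM to 16000 nM.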

Compound 3, concentration for 50% growth inhibition: 5300 nM
Estimate against measurement, compound 3: 1.3-fold (0.12 log units) below; measured number inside the range.
By their numbers in this assay, from the lowest: compounds 2 and 3 (each within the scatter of the next); then compound 1.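

In this assay the turn of the double bond from E to Z gives a 1.6-fold higher number from compound 2 to compound 3 (0.19 log units; within the scatter) and so the two forms cannot be told apart on this read-out. The exchange of cyclohexyl for 4-chlorophenyl gave a 5.3-fold lower number from compound 1 to compound 2 (0.72 log units; beyond the scatter) while the change of configuration at that same double bond stays inside the scatter, so in these three compounds the group on the double bond moves the number and its geometry does not. The comparison is a clean one, as nothing else varies within the pair: the fact that compounds 2 and 3 differ only in the configuration as drawn

The compounds shown leave open whether the cyclohexyl compound would respond the same way to a turn of its double bond, and what happens when the acetate ester gives way to a free alcohol, an amine or a carboxylic acid. They also do not tell whether the chlorine on either ring could be replaced by a methoxy group without moving the number beyond the scatter.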